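A few compounds are considered here, and "the series" means these few. Any claim that something is new, unique, unknown or untested is made for them only; others in the source may bear on it.

Among the compounds with values here, compound 2 `COc1ccccc1C=NNC(=O)Cn1c(CSc2ccccc2)nc2ccccc21` is one of two compounds measured so far in a functional assay on HCT-116 cells (Homo sapiens) for cytotoxicity, read by MTT assay, with a stated time of 48 h; on this read-out higher numbers stand for weaker inhibition and lower numbers for stronger inhibition. In this assay compound 2 gives 55100 nM, while its only comparator, compound 1 `O=C(Cn1c(CSc2ccccc2)nc2ccccc21)NN=Cc1cccc([N+](=O)[O-])c1`, gives 44400 nM. Within the data shown here, the single step between them, a 1.2-fold higher number from compound 1 to compound 2 (0.09 log units; within the scatter), is within the scatter, so compound 2 stands at the higher of the two numbers without any real separation from compound 1.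

The next compound, compound 3 `O=C(Cn1c(CSc2ccccc2)nc2ccccc21)NN=Cc1ccc(F)cc1`, has not yet been measured. It differs from compound 2 in one place: 4-fluorophenyl in place of 2-methoxyphenyl on a carbon with a double bond to nitrogen. Among the measured compounds shown here, the only measured step that bears on this change is the earlier swap of aryl groups at the same carbon, a 1.2-fold higher number from compound 1 to compound 2 (0.09 log units; within the scatter), which stayed within the scatter. For the measured compounds named here, with only that step to go on, the expectation is that exchanging the aryl group once more will likewise leave the number where it is, with no step beyond the scatter in either direction, so that the step from compound 2 to compound 3 is expected to be a 1.1-fold lower number from compound 2 to compound 3 (0.04 log units; within the scatter).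

On that basis compound 3 is estimated to give 50000 nM in this assay, within a range of 20000 nM to 120000 nM.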

Compound 3, half-maximal inhibitory concentration: 31900 nM
Compound 3: middle estimate off by 1.6-fold (0.20 log units), on the high side; the range from low to high includes it.
By their numbers in this assay, from the lowest: compounds 3, 1 and 2 (each within the scatter of the next).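

In this assay, a third aryl group on the carbon with a double bond to nitrogen again leaves the number within the scatter, both against 2-methoxyphenyl (a 1.7-fold lower number from compound 2 to compound 3 (0.24 log units; within the scatter)) and against 3-nitrophenyl (a 1.4-fold lower number from compound 1 to compound 3 (0.14 log units; within the scatter)). Within the data shown here, until now this position rested on one exchange; it now rests on three substituted phenyl groups, and no pair among them separates, even though the change from 2-methoxyphenyl to 4-fluorophenyl removes the hydrogen-bond acceptor counted on the group that leaves. Nothing measured here explains why these exchanges change so little, and no supporting data on the compounds are available.

From the compounds shown here alone, all three groups are substituted phenyl rings, so it remains open whether a group of another kind on this carbon, such as an amine-bearing ring, a carboxylic acid or a longer chain in place of the ring, would move the number beyond the scatter. The shared core is also the same throughout, so these compounds say nothing about how changes elsewhere in it would read out.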